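The source may hold more compounds than are shown below. What is called first, only, known or untested is meant among the compounds shown, and "the series" means these compounds.

Compound 2 `Cn1nc(-c2ccc(OC[C@H]3CC[C@@H](N)CC3)c(F)c2)c2cnc(N)nc21` gives 20 nM in an assay on THP-1 cells for antagonist activity at Toll-like receptor 8 (Homo sapiens) (a lower number here means a stronger inhibitor, a higher number a weaker inhibitor), the higher of the two numbers recorded here, while compound 1 `Cc1cc(-c2nn(C)c3nc(N)ncc23)cnc1OCC12CCC(N)(CC1)CC2` gives 1 nM, a gap beyond the usual scatter. Compound 3 `Cn1nc(-c2ccc(OCC3CC4(CNC4)C3)c(F)c2)c2cnc(N)nc21` differs from compound 2 in one place: a group of 7 heavy atoms (6 carbon, 1 nitrogen; one four-membered non-aromatic ring of carbon only, one four-membered non-aromatic ring with 1 hetero atom) in place of a group of 7 heavy atoms (6 carbon, 1 nitrogen; one six-membered non-aromatic ring of carbon only), on a saturated chain carbon bound to an oxygen on an aromatic ring. Going by the values given here, no measured pair shows this change, so the expectation rests on compound 2 alone and on the change itself, which swaps one saturated ring system for another of the same heavy-atom count. The step is expected to stay within the scatter, a 1.3-fold higher number from compound 2 to compound 3 (0.10 log units; within the scatter). Compound 3 is therefore estimated at 25 nM in this assay, between 8 nM and 80 nM.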

Compound 3, half-maximal inhibitory concentration: 10 nM
Estimate against measurement, compound 3: 2.5-fold (0.40 log units) above, within the range that was stated.
By their numbers in this assay, from the lowest: compound 1; then compounds 3 and 2 (each within the scatter of the next).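

In this assay the swap of the 4-aminocyclohexyl group for the group with two four-membered non-aromatic rings, on a saturated chain carbon bound to an oxygen on an aromatic ring, gives a 2.0-fold lower number from compound 2 to compound 3 (0.30 log units; within the scatter) and so shows that this position takes a quite different saturated ring system of equal heavy-atom count with no change beyond the scatter. Nothing available accounts for this result. As far as these compounds go, whether the position would also hold a carboxylic acid in place of the amine, or a longer chain leading to the ring, stays open.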